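The compounds below may be only part of what the source reports. "The series", "measured", "known", "first", "only" and "open" are said of these compounds alone.

Compounds measured so far:
- compound 1, `CN(C)C(=O)c1cc2cnc(Nc3ccc(C(=O)NCCCCCCN=C=S)cc3)nc2n1C1CCCC1`: 35.8%
- compound 2, `CN(C)C(=O)c1cc2cnc(Nc3ccc(C(=O)NCCCN=C=S)cc3F)nc2n1C1CCCC1`: 16.7%
- compound 3, `CN(C)C(=O)c1cc2cnc(Nc3ccc(C(=O)NCCCCCN=C=S)cc3F)nc2n1C1CCCC1`: -1.6%

In a functional assay on A549 cells (Homo sapiens) for inhibition, read by CCK-8 assay, with a stated time of 72 h, tested at 1 uM (on this read-out lower numbers stand for a weaker effect and higher numbers for a stronger effect at the one concentration tested), compound 3 gives the lowest number of the three. Compound 2 stands closest to it, and compound 1 stands furthest away, each of these gaps lying beyond the scatter.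

Compound 4, `CN(C)C(=O)c1cc2cnc(Nc3ccc(C(=O)NCCCCCCN=C=S)cc3F)nc2n1C1CCCC1`, has not yet been measured. Its structure differs from that of compound 3 in one place: a group of 4 heavy atoms (2 carbon, 1 nitrogen, 1 sulfur; no ring) in place of a group of 3 heavy atoms (1 carbon, 1 nitrogen, 1 sulfur; no ring), on a saturated chain carbon, five bonds along the chain from an amide-type nitrogen. Among the measured compounds shown here, only one measured step bears on this kind of change. It lengthened the same chain by more than the present step does, and it gave a number 18.3 percentage points lower from compound 2 to compound 3 (beyond the scatter). A second lengthening of the chain, smaller than that one, is therefore expected to move the number little, if at all, and if it moves, slightly downward; the expected step is a number 3.6 percentage points higher from compound 3 to compound 4 (within the scatter), within the scatter. Compound 4 is thus estimated at 2% in this assay, with a range from -15% to 25%.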

Compound 4, a percentage reported as inhibition, at one concentration (the size of the read-out at that concentration, not a potency): -11.8%
Compound 4: middle estimate off by 13.8 percentage points, on the high side; the measured number falls inside the stated range.
By their numbers in this assay, from the lowest: compound 4; then compound 3; then compound 2; then compound 1.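

In this assay, lengthening the chain again lowers the number once more: a number 10.2 percentage points lower from compound 3 to compound 4 (beyond the scatter), and across the three compounds carrying fluoro, a number 28.5 percentage points lower from compound 2 to compound 4 (beyond the scatter). The earlier compounds shown here showed a single fall, whereas compound 2, compound 3 and compound 4 now form a steady downward run, with no levelling off at this chain length. Among the compounds shown here, the result also gives the first direct reading of the fluoro change with the chain held the same, and it is the largest step here: a number 47.6 percentage points lower from compound 1 to compound 4 (beyond the scatter).

Nothing measured here explains either the fall along the chain or the fall with fluoro. Going by these compounds, it remains open whether a longer chain would extend the run, whether an amine on the chain would follow it, and whether fluoro in place of hydrogen gives a step of similar size on shorter chains.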